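A Methoxy Added Next to the Hydroxy of Compound 1

A few compounds are considered here, and "the series" means these few. Any claim that something is new, unique, unknown or untested is made for them only; others in the source may bear on it.

Compound 1, `CC1=CC[C@H](C(C)(C)NC(=S)N/N=C/c2ccc(O)cc2)CC1`: > 100000 nM
Compound 2, `CC1=CC[C@H](C(C)(C)NC(=S)N/N=C/c2ccc(Cl)cc2)CC1`: 70500 nM

Both measured compounds were tested in a functional assay on HT-29 cells (Homo sapiens) for inhibition, read by sulforhodamine B assay, with a stated time of 48 h; on this read-out lower numbers stand for stronger inhibition of growth and higher numbers for weaker inhibition of growth. For compound 1 the assay records only a limit, > 100000 nM, not a number. Compound 1 thus stands at the limit of > 100000 nM in this assay, at which 1 of the 2 values shown sits. Compound 2 gives 70500 nM. For the measured compounds named here, the single measured step, an at least 1.4-fold lower number from compound 1 to compound 2 (0.15 log units; that floor lies within the scatter), starts from a limit, so its true size is not known beyond that floor; it does show that swapping the hydroxy for chloro left growth inhibition weak.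

Compound 3, `COc1cc(/C=N/NC(=S)NC(C)(C)[C@H]2CC=C(C)CC2)ccc1O`, keeps the core of compound 1 and differs from it by methoxy in place of hydrogen on an aromatic carbon. Going by the values given here, no measured step adds a methoxy group, so the change from compound 1 to compound 3 has no direct precedent; the only guide is that the one measured change, to compound 2, stayed weak. A step of no size beyond the scatter is therefore expected, a number no higher from compound 1 to compound 3 (the limit leaves the size open). Compound 3 is estimated at 100000 nM, within a range from 40000 nM to 300000 nM, with a fair chance that only a limit is reported again.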

Compound 3, concentration for total growth inhibition: < 700 nM
Compound 3 gave a limit, no number; the forecaster's own chance of this, stated with the estimate: 55%; middle value at least 140-fold (2.15 log units) away from the limit.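

Methoxy in place of hydrogen on an aromatic carbon, ortho to a hydroxy group, gives an at least 140-fold lower number from compound 1 to compound 3 (2.15 log units; beyond the scatter) in this assay, so this one small addition to the ring can turn a compound with weak growth inhibition into a far stronger one. For the compounds shown here, the only earlier step, an at least 1.4-fold lower number from compound 1 to compound 2 (0.15 log units; that floor lies within the scatter), replaced the hydroxy itself and gave no sign that the ring could carry a change of this size. For compound 3 the assay records a limit and not a number, so the step is known only as a minimum: the limit of < 700 nM in this assay, at which 1 of the 3 values shown sits.

Whether an ethoxy group or an amine on this same carbon would act as methoxy does remains open, as does whether the neighbouring hydroxy group is needed for the change, since the compounds shown include no methoxy compound without it. Also open, as far as these compounds go, is how far the true value of compound 3 lies beyond its limit, and whether the same change would hold on cells other than those of this assay.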